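Neopentyl cyanoguanidines: methyl branching and minimum effective dose

The source may hold more compounds than are shown below. What is called first, only, known or untested is meant among the compounds shown, and "the series" means these compounds.

Measured compounds:
compound 1, `CCC/N=C(\NC#N)Nc1cccnc1`, gives 20 mg/kg
compound 2, `CC(C)C/N=C(\NC#N)Nc1cccnc1`, gives 20 mg/kg
compound 3, `CC(C)(C)C/N=C(/NC#N)Nc1cccnc1`, gives 2.5 mg/kg

All three numbers come from a functional assay on the whole organism (blood, strain Wistar-Okamoto) with Rattus norvegicus as the target, with a stated time of 5 days; on this read-out higher numbers stand for an effect only at larger amounts of compound and lower numbers for an effect already at smaller amounts. Compound 1 and compound 2 differ by methyl in place of hydrogen on a saturated chain carbon bound to two saturated chain carbons; the step of no change at the digits printed from compound 1 to compound 2 (within the scatter) shows that this addition left the read-out where it was. Compound 3 stands apart: its value is the lowest of the three, and the gap to compound 1 and to compound 2 lies beyond the scatter in each case. The difference between the core of compound 1 and the core of compound 3 is not broken down here.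

Compound 4, `CC(/N=C(/NC#N)Nc1cccnc1)C(C)(C)C`, is not yet measured. Relative to compound 3 it carries methyl in place of hydrogen on a saturated chain carbon bound to a double-bonded nitrogen and a saturated chain carbon. This is the same kind of change as that from compound 1 to compound 2, but the surroundings differ: in compound 2 the new methyl sits on a saturated chain carbon bound to two saturated chain carbons, whereas in compound 4 it sits on a saturated chain carbon bound to a double-bonded nitrogen and a saturated chain carbon.

In this assay, among the compounds with values here, compound 4 is expected to give about 3 mg/kg, with the step of a 1.2-fold higher number from compound 3 to compound 4 (0.08 log units; within the scatter) estimated to be small, because the only measured instance of a methyl for hydrogen exchange, no change at the digits printed from compound 1 to compound 2 (within the scatter), moved nothing. The different placement makes the range wide: the estimate for compound 4 spans from 1 mg/kg to 10 mg/kg.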

Compound 4, minimum effective dose: 1 mg/kg
Estimate against measurement, compound 4: 3.0-fold (0.48 log units) above; low and high end bracket the measured number.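

In this assay, methyl in place of hydrogen on a saturated chain carbon bound to a double-bonded nitrogen and a saturated chain carbon gives a 2.5-fold lower number from compound 3 to compound 4 (0.40 log units; beyond the scatter), so the change from neopentyl to 1,2,2-trimethylpropyl is a modest step that stands clear of the usual scatter. Set beside the earlier methyl exchange, the new step cannot be told apart from it, although only the new step lies beyond the scatter on its own: the same change on two cores in this assay, no change at the digits printed (within the scatter) from compound 1 to compound 2 and a 2.5-fold lower number (0.40 log units; beyond the scatter) from compound 3 to compound 4, 2.5-fold (0.40 log units) apart, within the scatter of two such steps. This does not show that the exchange carries over unchanged from one core to another, nor that its size depends on the core, as each core supplies a single pair and the new methyl sits on a differently bound carbon in each pair.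

Still open, going by these compounds, is whether a methyl on the saturated chain carbon bound to a double-bonded nitrogen and a saturated chain carbon would give a step of the same size on the core of compound 1 or compound 2. Also open, on these data alone, is whether an ethyl group or a longer chain in place of the new methyl in compound 4 would extend the step or reverse it.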